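A few compounds are considered here, and "the series" means these few. Any claim that something is new, unique, unknown or untested is made for them only; others in the source may bear on it.

Measured in a functional assay on NCI-H460 cells (Homo sapiens) for antiproliferative activity; on this read-out lower numbers stand for stronger inhibition and higher numbers for weaker inhibition:
- compound 1 `COc1ccc(S(=O)(=O)Oc2ccccc2NC(=O)c2ccncc2)cc1`: 55 nM
- compound 2 `COc1ccc(S(=O)(=O)Oc2ccccc2NC(=O)c2ccccn2)cc1`: 300 nM
- compound 3 `COc1ccc(S(=O)(=O)Oc2ccccc2NC(=O)c2ccc(F)cc2)cc1`: 550 nM

The three compounds share one core and differ only in the group on the carbonyl carbon. Compound 3 belongs with compound 2 on these numbers, since the gap between them is a 1.8-fold higher number from compound 2 to compound 3 (0.26 log units; within the scatter), which lies within the scatter. Compound 1 stands apart from both, with a 5.5-fold higher number from compound 1 to compound 2 (0.74 log units; beyond the scatter) and a 10-fold higher number from compound 1 to compound 3 (1.00 log units; beyond the scatter).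

Compound 4 `COc1ccc(S(=O)(=O)Oc2ccccc2NC(=O)Oc2ccccc2)cc1` keeps the shared core and carries phenoxy in place of 4-fluorophenyl on a carbonyl carbon whose other neighbour is the amide-type nitrogen: phenoxy in place of 4-fluorophenyl on a carbonyl carbon.

Within the data shown here, no measured compound carries phenoxy, so no measured step shows this exchange directly. The steps at this carbonyl carbon show that the group there can matter, but only the two steps away from compound 1 go beyond the scatter. Among the measured compounds shown here, the one exchange that does not involve compound 1, a 1.8-fold higher number from compound 2 to compound 3 (0.26 log units; within the scatter), stays within it. On that basis, no step beyond the scatter is expected in this assay, and the direction is left open. The estimated step is a 1.1-fold higher number from compound 3 to compound 4 (0.04 log units; within the scatter). For compound 4 the expected value is 600 nM, with an estimated range from 150 nM to 2500 nM.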

Compound 4, half-maximal inhibitory concentration: > 10000 nM
Compound 4: only a limit was reported; the forecaster's own chance of this, stated with the estimate: 5%; middle value at least 16-fold (1.22 log units) away from the limit.
By their numbers in this assay, from the lowest: compound 1; then compounds 2 and 3 (each within the scatter of the next). At a limit, above all of these: compound 4.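

In this assay compound 4 is reported only as a limit and not as a number: the limit of > 10000 nM in this assay, at which 1 of the 4 values shown sits. The earlier steps shown here at this carbonyl carbon were modest at most, whereas phenoxy in place of 4-fluorophenyl gives a large one, an at least 18-fold higher number from compound 3 to compound 4 (1.25 log units; beyond the scatter), even though each of these two groups holds one six-membered aromatic ring of carbon only. Against the two pyridinyl groups the steps are also large, with an at least 33-fold higher number from compound 2 to compound 4 (1.52 log units; beyond the scatter) and an at least 180-fold higher number from compound 1 to compound 4 (2.25 log units; beyond the scatter), so a single exchange at this position can carry the number as far as the limit of the assay.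

The compounds shown leave open whether an anilino group or a benzyl group on this carbonyl carbon would also reach that limit, or would stay with the aryl groups of compounds 1 to 3. They also leave open how far compound 4 really lies from the others, and whether a substituent on the phenoxy ring, such as a fluorine atom or a methoxy group, would change this result.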